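Working notes: aryl swap on the triazole nitrogen, compound 2 to 3

This account rests on a few compounds, and the source may have more. Where it says the series, first, only, none or still open, it means among the compounds named here.

Measured compounds:
compound 1 `N#CC1=C(N)Oc2c(c3nc4ccccc4nc3c3ccccc23)C12C(=O)N(Cc1cnnn1-c1ccc(N)cc1)c1ccccc12`: in a functional assay on A549 cells (Homo sapiens) for antiproliferative activity, read by MTT assay, with a stated time of 48 h (a higher number here means a weaker inhibitor, a lower number a stronger inhibitor), compound 1 gives a limit, > 50000 nM.
compound 2 `N#CC1=C(N)Oc2c(N)cc3nc4ccccc4nc3c2C12C(=O)N(Cc1cnnn1-c1ccc(F)cc1)c1ccccc12`: in this assay compound 2 gives a limit, > 50000 nM.

Compound 2 stands nowhere on a numerical scale in this assay: its value is a limit of the assay, not a number. The same holds for compound 1, so the two values together show only (the limit of > 50000 nM in this assay, at which 2 of the 2 values shown sit). Going by the values given here, with both values at the limit, no step between measured compounds can be stated, and nothing in these two numbers tells whether the shared core can be brought to a measurable half-maximal inhibitory concentration by a change on the aryl group of the triazole.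

Compound 3 `COc1ccccc1-n1nncc1CN1C(=O)C2(C(C#N)=C(N)Oc3c(N)cc4nc5ccccc5nc4c32)c2ccccc21` differs from compound 2 in one place: 2-methoxyphenyl in place of 4-fluorophenyl on an aromatic nitrogen, in words 2-methoxyphenyl in place of 4-fluorophenyl on an aromatic nitrogen. Among the compounds with values here, since compound 2 sits at the limit and no measured step gives a direction, no change beyond the scatter is expected from compound 2 to compound 3, and the most likely outcome is a further limit. Compound 3 is therefore estimated at 60000 nM, with a range from 15000 nM to 250000 nM, which means an expected step that the limit leaves unreadable from compound 2 to compound 3.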

Compound 3, half-maximal inhibitory concentration: 37500 nM
Beside the measured number, compound 3's estimate is 1.6-fold (0.20 log units) above it, within the range that was stated.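

In this assay, going by these compounds alone, compound 3 gives 37500 nM, the only value shown so far that is a number and not a limit of the assay, so the shared core can reach a measurable half-maximal inhibitory concentration with 2-methoxyphenyl on the aromatic nitrogen. For 2-methoxyphenyl in place of 4-fluorophenyl the data give an at least 1.3-fold lower number from compound 2 to compound 3 (0.12 log units; that floor lies within the scatter), which means that a gain in potency from this change is not established. The true size of the step cannot be read any further, because the value of compound 2 is only a limit: the limit of > 50000 nM in this assay, at which 2 of the 3 values shown sit.

Open is whether the methoxy group itself or some other feature of the 2-methoxyphenyl group goes with the measurable value, since the one step shown changes the whole aryl group at once. Also open, as far as these compounds go, is how far the number in this assay moves at this position with a plain phenyl, or with a carboxylic acid or a longer alkoxy chain on the aryl ring.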